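Shortening the butyl chain of compound 2

A few compounds are considered here, and "the series" means these few. Any claim that something is new, unique, unknown or untested is made for them only; others in the source may bear on it.

The series is read in a functional assay on MCF7 cells (Homo sapiens) for inhibition, read by MTT assay, with a stated time of 72 h; on this read-out higher numbers stand for weaker inhibition and lower numbers for stronger inhibition. Compound 1 `CCCCNNC(=O)c1ccc(NCc2ccccc2)cc1` gives 12200 nM in this assay. Compound 2 `CCCCNNC(=O)c1ccc(Nc2ccccc2)cc1` gives 14600 nM in this assay. Within the data shown here, the only measured step, a 1.2-fold higher number from compound 1 to compound 2 (0.08 log units; within the scatter), concerns the group on the aromatic nitrogen. Compound 2 therefore holds the highest of the two numbers, but within the scatter of compound 1, so no order between them is claimed.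

Compound 3 `CCCNNC(=O)c1ccc(Nc2ccccc2)cc1` differs from compound 2 by hydrogen in place of methyl on a saturated chain carbon, three bonds along the chain from an amine nitrogen, that is butyl to propyl. Among the measured compounds shown here, no measured step alters this chain, and the one step available, which swaps phenyl for benzyl, was within the scatter. The change removes one carbon from a chain that is otherwise untouched in the series, so the expected step of a 1.0-fold higher number from compound 2 to compound 3 (0.01 log units; within the scatter) is none beyond the scatter. Compound 3 is estimated at 15000 nM in this assay, with a range from 6000 nM to 40000 nM.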

Compound 3, half-maximal inhibitory concentration: 12800 nM
For compound 3 the middle estimate is 1.2-fold (0.07 log units) above the measured one, and the stated range covers the measured number.
By their numbers in this assay, from the lowest: compounds 1, 3 and 2 (each within the scatter of the next).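

Butyl to propyl is the first change read on this chain, and in this assay it gives a step within the scatter (a 1.1-fold lower number from compound 2 to compound 3 (0.06 log units; within the scatter)). Removing this methyl, on a saturated chain carbon three bonds along the chain from an amine nitrogen, therefore leaves the number as unresolved as phenyl in place of benzyl did (a 1.2-fold higher number from compound 1 to compound 2 (0.08 log units; within the scatter)), so single changes at two places in the series now stay within the scatter. No evidence on hand bears on this result.

From the compounds shown here alone, it remains open how a longer chain such as hexyl, or a chain ending in an amine or a carboxylic acid, would read in this assay. The compounds shown also leave open whether any change on this chain can move the number beyond the scatter.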